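The source may report more compounds than this note shows. Statements on the series, on what has been measured and on what is new or still open speak of the compounds shown alone.

Measured so far in a physicochemical assay for solubility, in phosphate buffer, measured as kinetic solubility, at pH 7.4; a higher number here means a more soluble compound, a lower number a less soluble compound:
- compound 1 `Cc1cccc(-c2nc(CN3CCC(C(=O)NCCCN4C[C@H](C)C[C@H](C)C4)CC3)c(C)o2)c1` gives > 69 ug/mL (a limit)
- compound 2 `COc1cccc(Br)c1-c1nc(CN2CCC(C(=O)NCCCN3C[C@H](C)C[C@H](C)C3)CC2)c(C)o1` gives > 83 ug/mL (a limit)
- compound 3 `CCc1ccccc1-c1nc(CN2CCC(C(=O)NCCCN3C[C@H](C)C[C@H](C)C3)CC2)c(C)o1` gives 55.9 ug/mL (a number)

Of these three, compound 3 alone has a number, and the other two stand at limits. Compound 4 `COc1cccc(F)c1-c1nc(CN2CCC(C(=O)NCCCN3C[C@H](C)C[C@H](C)C3)CC2)c(C)o1` has not yet been measured. It differs from compound 3 in one place: 2-fluoro-6-methoxyphenyl in place of 2-ethylphenyl on an aromatic carbon.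

For the measured compounds named here, two measured steps bear on this change. Compound 2 carries 2-bromo-6-methoxyphenyl, the group most like the incoming one, and the step of an at least 1.4-fold lower number from compound 2 to compound 3 (0.17 log units; that floor lies within the scatter) gives only a floor within the scatter. Likewise, an at least 1.2-fold lower number from compound 1 to compound 3 (0.09 log units; that floor lies within the scatter) gives only a floor within the scatter. A slight rise in this assay is therefore expected, but none beyond the scatter. The expected step is a 1.2-fold higher number from compound 3 to compound 4 (0.09 log units; within the scatter). A limit may well appear instead of a number. For compound 4 the estimate is 68 ug/mL with an expected range of 45 ug/mL to 90 ug/mL in this reading.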

Compound 4, solubility: > 74 ug/mL
Compound 4: a limit, no number; the forecaster's own chance of this, stated with the estimate: 55%; middle value at least 1.0-fold (0.03 log units) from the limit.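

In this assay, from the compounds shown here alone, putting 2-fluoro-6-methoxyphenyl in place of 2-ethylphenyl on the aromatic carbon gives an at least 1.3-fold higher number from compound 3 to compound 4 (0.12 log units; that floor lies within the scatter), so this change can be bounded on one side only and its true size stays unknown. Compound 4 ends at a limit and not at a number: the limit of > 74 ug/mL in this assay, at which 1 of the 4 values shown sits. Fluoro in place of bromo leaves this position at a limit as well, so the steps to compound 4 from compound 1 and from compound 2 cannot be read, and the fluoro and bromo groups cannot be ranked.

Going by these compounds, how far compound 4 lies past its limit remains open. Also open, on these data alone, is what a 2-fluorophenyl group without the methoxy, or a phenyl group carrying a carboxylic acid, would give at this position in this assay.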